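The source may hold more compounds than are shown below. What is called first, only, known or untested is meant among the compounds shown, and "the series" means these compounds.

Compound 3 `Cc1ccc2[nH]c(=O)c(/C=N/N)cc2c1` gives 153000 nM in a functional assay, read by spectrophotometry, with a stated time of 5 min (on this read-out lower numbers stand for stronger inhibition and higher numbers for weaker inhibition), the lowest of the three numbers shown, although it lies within the scatter of both compound 1 `Cc1ccc2[nH]c(=O)c(/C=N/c3ccccc3O)cc2c1`, which gives 286000 nM, and compound 2 `O=c1[nH]c2ccccc2cc1/C=N/c1ccc(O)cc1`, which gives 306000 nM. Compound 4 `Cc1ccc2[nH]c(=O)c(/C=N/c3ccc(O)cc3)cc2c1` differs from compound 3 by 4-hydroxyphenyl in place of amino on a double-bonded nitrogen. Among the compounds with values here, only one measured step bears on this change, and it runs the opposite way: a 1.9-fold lower number from compound 1 to compound 3 (0.27 log units; within the scatter). That step stayed within the scatter, so putting a hydroxyphenyl group back in place of the amino group is expected to move the number little, if at all. The estimated step is a 1.9-fold higher number from compound 3 to compound 4 (0.28 log units; within the scatter). Compound 4 is therefore expected to give about 290000 nM, with a likely range from 150000 nM to 600000 nM.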

Compound 4, half-maximal inhibitory concentration: 235000 nM
Compound 4: the middle estimate sits 1.2-fold (0.09 log units) above what was measured; measured number inside the range.
By their numbers in this assay, from the lowest: compounds 3, 4, 1 and 2 (each within the scatter of the next).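

Placing 4-hydroxyphenyl on the double-bonded nitrogen in place of amino gives a 1.5-fold higher number from compound 3 to compound 4 (0.19 log units; within the scatter), so a full aromatic ring and a single amino group cannot be told apart at this position in this assay. The hydroxyl's place on that ring gives a 1.2-fold lower number from compound 1 to compound 4 (0.09 log units; within the scatter), and methyl in place of hydrogen on the core gives a 1.3-fold lower number from compound 2 to compound 4 (0.11 log units; within the scatter), so neither change can be told from the scatter either.

No supporting data offer an explanation for this flat picture. On these data alone, whether a carboxylic acid or a longer alkyl chain on that nitrogen would move the number beyond the scatter remains open.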